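The source may report more compounds than this note shows. Statements on the series, on what has been measured and on what is new or still open speak of the compounds shown alone.

Working notes on the series. Compound 2 `COc1ccc(C(O)(Cc2ccc(F)cc2)c2cccc3ccccc23)c(OC)c1OC` gives 5440 nM in a functional assay on MDA-MB-231 cells (Homo sapiens) for inhibition, read by sulforhodamine B assay, with a stated time of 48 h; on this read-out lower numbers stand for stronger inhibition and higher numbers for weaker inhibition. Compound 1 `COc1ccc(C(O)(Cc2ccc(C)cc2)c2cccc3ccccc23)c(OC)c1OC` returns only a limit in this assay, > 20000 nM. On these data alone, the change between them is methyl in place of fluoro on an aromatic carbon, and the step reads an at least 3.6-fold higher number from compound 2 to compound 1 (0.56 log units; beyond the scatter); how far it reaches is capped by the limit of > 20000 nM in this assay, at which 2 of the 3 values shown sit, so the true size of the step is unknown. Compound 3 `COc1ccc(/C(=C/c2ccc(F)cc2)c2cccc3ccccc23)c(OC)c1OC` also sits at a limit in this assay, > 20000 nM. The difference between the cores of compound 2 and compound 3 is not broken down here. Compound 4 `COc1ccc(/C(=C/c2ccc(C)cc2)c2cccc3ccccc23)c(OC)c1OC` is not yet measured; its change from compound 3 is methyl in place of fluoro on an aromatic carbon, the same change as that from compound 2 to compound 1. Compound 3 already stands at a limit, and the earlier step moved toward weaker inhibition. The step that the limit leaves unreadable from compound 3 to compound 4 is therefore expected to keep compound 4 at or beyond that limit. Compound 4 is estimated at 40000 nM, between 20000 nM and 120000 nM, most likely reported only as a limit.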

Compound 4, half-maximal inhibitory concentration: 8310 nM
Estimate against measurement, compound 4: 4.8-fold (0.68 log units) above; measured number outside the range, below it.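

In this assay, methyl in place of fluoro does not carry over from one core to the other with the same outcome: the new step reads an at least 2.4-fold lower number from compound 3 to compound 4 (0.38 log units; beyond the scatter). The two pairs shown run in opposite directions, so the earlier step cannot be transferred to the other core: the same change on two cores in this assay, an at least 3.6-fold higher number (0.56 log units; beyond the scatter) from compound 2 to compound 1 and an at least 2.4-fold lower number (0.38 log units; beyond the scatter) from compound 3 to compound 4, at least 8.8-fold (0.94 log units) apart, beyond the scatter of two such steps Each step has a limit at one end, so only a direction and a minimum size can be read, and the true sizes remain unknown: the limit of > 20000 nM in this assay, at which 2 of the 4 values shown sit.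

On these data alone, it remains open whether chloro or an amine in the same place would also give opposite directions on these two cores. The data also do not show which difference between the cores goes with the reversal.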